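Chloro in place of trifluoromethyl on the amine-bound aryl

This account rests on a few compounds, and the source may have more. Where it says the series, first, only, none or still open, it means among the compounds named here.

Three measured members of the shared core differ only in the aryl group on an amine nitrogen in a ring. Compound 1 `Nc1scc(CN2CCN(c3cccc(C(F)(F)F)c3)CC2)c1C(=O)c1ccc(Cl)cc1` gives 0% in an assay on CHO cells for displacement of a labelled ligand from adenosine receptor A1 (Homo sapiens), read by scintillation counting, with a stated time of 120 min, tested at 10 uM; a higher number here means more inhibition at the concentration tested (going by the name of the read-out), a lower number less inhibition. Compound 2 `Nc1scc(CN2CCN(c3ccccc3C(F)(F)F)CC2)c1C(=O)c1ccc(Cl)cc1` gives 0% in this assay, and compound 3 `Nc1scc(CN2CCN(c3cccc4ccccc34)CC2)c1C(=O)c1ccc(Cl)cc1` gives 1% in this assay. Compound 2 is level with compound 1 at the digits reported, and together they are the lowest of the three numbers; the nearest neighbour is compound 1 with no change at the digits printed from compound 1 to compound 2 (within the scatter), the furthest compound 3 with a number 1 percentage points higher from compound 2 to compound 3 (within the scatter). The remaining step, a number 1 percentage points higher from compound 1 to compound 3 (within the scatter), also lies within the scatter, so all three aryl exchanges on this nitrogen leave the read-out flat.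

Compound 4 `Nc1scc(CN2CCN(c3ccccc3Cl)CC2)c1C(=O)c1ccc(Cl)cc1` differs from compound 2 by chloro in place of trifluoromethyl on an aromatic carbon. Within the data shown here, the steps that bear on this are the three aryl exchanges at the same position, none of which moved the number beyond the scatter; the present change is confined to one substituent on that aryl, so no step beyond the scatter is expected. The step from compound 2 to compound 4 is therefore expected to be a number 1 percentage points higher from compound 2 to compound 4 (within the scatter). Compound 4 is estimated to give 1% in this assay, with an expected range from 0% to 10%.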

Compound 4, a percentage reported as inhibition, at one concentration (the size of the read-out at that concentration, not a potency): 2%
Compound 4: middle estimate off by 1 percentage points, on the low side, within the range that was stated.
By their numbers in this assay, from the lowest: compounds 1, 2, 3 and 4 (each within the scatter of the next).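

Exchanging trifluoromethyl for chloro, a group with fewer heavy atoms, on an aromatic carbon of the aryl gives a number 2 percentage points higher from compound 2 to compound 4 (within the scatter) in this assay. The read-out at this position therefore stays inside the scatter for a change to one substituent as well as for exchanges of the whole aryl, and the comparisons with the other aryl groups agree: a number 1 percentage points higher from compound 3 to compound 4 (within the scatter) and a number 2 percentage points higher from compound 1 to compound 4 (within the scatter) are the steps, so 2-chlorophenyl cannot be told apart from 3-(trifluoromethyl)phenyl or naphthalen-1-yl on this nitrogen. No measurement is available that bears on why this exchange leaves the read-out inside the scatter.

Still open is whether any substituent on this aryl can lift the read-out clear of the scatter, as a methoxy group, a hydroxyl group, an amine or a carboxylic acid lies outside the compounds shown. Also open, as far as these compounds go, is whether aryl exchanges on this nitrogen would register on a different core, as all four compounds share one core and all sit within the scatter of each other in this assay.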